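Fluoro for Chloro on the Sulfonyl Ring

The source may hold more compounds than are shown below. What is called first, only, known or untested is meant among the compounds shown, and "the series" means these compounds.

The measured compounds:
Compound 1 `COc1ccc(Cc2nnc(NC(=O)/C(C#N)=C/c3ccccc3OS(=O)(=O)c3ccc(Cl)cc3)s2)cc1` gives 34% in an ADME assay on HEK-293T cells (Homo sapiens) for inhibition, read by CCK-8 assay, with a stated time of 48 h, tested at 20 uM; a lower number here means less inhibition of growth, a higher number more inhibition of growth at the concentration tested.
Compound 2 `COc1ccc(Cc2nnc(NC(=O)/C(C#N)=C/c3ccccc3OS(=O)(=O)c3ccc(F)cc3)s2)cc1` gives 6% in this assay.
Compound 3 `N#C/C(=C\c1ccccc1OS(=O)(=O)c1ccc(Cl)cc1)C(=O)Nc1nnc(Cc2ccccc2)s1` gives 25% in this assay.

Compound 1 and compound 2 share a core and differ by one change, (fluoro in place of chloro on an aromatic carbon). That change made a step of a number 28 percentage points lower from compound 1 to compound 2 (beyond the scatter). Compound 3 carries a different core; the difference between the two cores is hydrogen in place of methoxy on an aromatic carbon, and it gave a step of a number 9 percentage points lower from compound 1 to compound 3 (within the scatter). Compound 4 `N#C/C(=C\c1ccccc1OS(=O)(=O)c1ccc(F)cc1)C(=O)Nc1nnc(Cc2ccccc2)s1` is not yet measured. It differs from compound 3 by fluoro in place of chloro on an aromatic carbon, and since the surroundings of the place read the same as for the change from compound 1 to compound 2, it is the same change. The expectation for compound 4 rests on that one precedent: the step from compound 3 is estimated as a number 20 percentage points lower from compound 3 to compound 4 (beyond the scatter), beside the earlier step of a number 28 percentage points lower from compound 1 to compound 2 (beyond the scatter), which shares the change. Compound 4 is therefore estimated at 5% in this assay, with a likely range from 0% to 18%.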

Compound 4, percent growth inhibition at one concentration: 6%
Estimate against measurement, compound 4: 1 percentage points below; low and high end bracket the measured number.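

In this assay, fluoro in place of chloro on the sulfonyl ring gave a number 19 percentage points lower from compound 3 to compound 4 (beyond the scatter), and this step agrees with the one seen on the core that carries the methoxy group: the same change on two cores in this assay, a number 28 percentage points lower (beyond the scatter) from compound 1 to compound 2 and a number 19 percentage points lower (beyond the scatter) from compound 3 to compound 4, 9 percentage points apart, within the scatter of two such steps. Hydrogen in place of methoxy, read on the two fluoro compounds, gave no change at the digits printed from compound 2 to compound 4 (within the scatter), and this too agrees with its counterpart on the two chloro compounds: the same change on two cores in this assay, a number 9 percentage points lower (within the scatter) from compound 1 to compound 3 and no change at the digits printed (within the scatter) from compound 2 to compound 4, 9 percentage points apart, within the scatter of two such steps. The change therefore carried over between these two cores, but they differ in only one place, so this does not show that it would hold on a core altered elsewhere, and the steps themselves identify no cause.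

The compounds shown leave open how a bromo group or an amine would read at the same place on the sulfonyl ring, where only chloro and fluoro appear. Also open, going by these compounds, is whether the step from chloro to fluoro would hold with a carboxylic acid or a longer chain in place of the methoxy group.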